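A few compounds are considered here, and "the series" means these few. Any claim that something is new, unique, unknown or untested is made for them only; others in the source may bear on it.

Working notes on the series.

Of the compounds shown here, three share the core and have been measured in an assay on microsomes from liver for inhibition of acyl-CoA desaturase 1 (Rattus norvegicus); a higher number here means a weaker inhibitor, a lower number a stronger inhibitor. Compound 1 `OCc1nnc(-c2ccc(N3CCC(Oc4ccccc4C(F)(F)F)CC3)nn2)s1` gives 3.2 nM. Compound 2 `CC(C)(C)c1nnc(-c2ccc(N3CCC(Oc4ccccc4C(F)(F)F)CC3)nn2)o1` gives 980 nM. Compound 3 `CC(C)Cc1nnc(-c2ccc(N3CCC(Oc4ccccc4C(F)(F)F)CC3)nn2)o1` gives 15 nM, which places it second highest of the three numbers, nearest compound 1 and furthest from compound 2. The measured steps are a 310-fold higher number from compound 1 to compound 2 (2.49 log units; beyond the scatter), a 4.7-fold higher number from compound 1 to compound 3 (0.67 log units; beyond the scatter) and a 65-fold lower number from compound 2 to compound 3 (1.82 log units; beyond the scatter).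

Compound 4 `Cc1nnc(-c2ccc(N3CCC(Oc4ccccc4C(F)(F)F)CC3)nn2)s1` is not yet measured. It differs from compound 3 by 5-methyl-1,3,4-thiadiazol-2-yl in place of 5-isobutyl-1,3,4-oxadiazol-2-yl on an aromatic carbon. For the measured compounds named here, two measured steps bear on this change. The step of a 65-fold lower number from compound 2 to compound 3 (1.82 log units; beyond the scatter) shows that the identity of the alkyl substituent on the five-membered ring matters greatly. The step of a 4.7-fold higher number from compound 1 to compound 3 (0.67 log units; beyond the scatter) shows that the thiadiazole bearing a small substituent gives a lower number than the oxadiazole bearing isobutyl, though that step changes both ring and substituent at once and cannot be split. Compound 4 combines the thiadiazole of compound 1 with a small methyl group; a modest lowering of the number from compound 3 is therefore expected, roughly back toward the value of compound 1, with the estimated step being a 2.5-fold lower number from compound 3 to compound 4 (0.40 log units; beyond the scatter). Going by the values given here, no measured compound carries a methyl on this ring, so the range is kept wide. For compound 4 in this assay the expected value is 6 nM, with a range from 1.5 nM to 25 nM.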

Compound 4, half-maximal inhibitory concentration: 2.3 nM
The estimate for compound 4 lay 2.6-fold (0.42 log units) above the measured number; the measured number falls inside the stated range.
By their numbers in this assay, from the lowest: compounds 4 and 1 (each within the scatter of the next); then compound 3; then compound 2.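

For the compounds shown here, for the first time the series has a step that changes only one place: on the thiadiazole, hydrogen in place of hydroxy on the saturated chain carbon gives a 1.4-fold lower number from compound 1 to compound 4 (0.14 log units; within the scatter) in this assay, so the hydroxy of the 5-(hydroxymethyl)-1,3,4-thiadiazol-2-yl group makes no readable difference to the number here. The 5-methyl-1,3,4-thiadiazol-2-yl group also stands well apart from both oxadiazoles, with a 6.5-fold lower number from compound 3 to compound 4 (0.81 log units; beyond the scatter) and a 430-fold lower number from compound 2 to compound 4 (2.63 log units; beyond the scatter), although each of these two steps changes the ring and its substituent together and neither can be split into those two parts.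

How much of the gap belongs to the sulfur-containing ring and how much to the substituent stays open, as would be settled by an isobutyl group on the thiadiazole or a methyl group on the oxadiazole, and the reach of the hydroxy result is equally open, since an amine, a carboxylic acid or a longer chain at that end of the thiadiazole substituent lies outside the compounds shown. Nothing at hand gives a reason for any of these steps.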